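A few compounds are considered here, and "the series" means these few. Any claim that something is new, unique, unknown or untested is made for them only; others in the source may bear on it.

Three compounds were measured in an ADME assay on A549 cells (Homo sapiens) for cytotoxicity, read by resazurin assay, with a stated time of 48 h; on this read-out lower numbers stand for higher toxicity in this test and higher numbers for lower toxicity in this test:

compound 1, `O=C(Nc1ccc(NCc2ccc(F)cc2)cc1Cl)c1cc(Cl)ccc1O`: 54400 nM
compound 2, `O=C(Nc1ccc(NCc2ccc(Cl)cc2)cc1Cl)c1cc(Cl)ccc1O`: 59700 nM
compound 3, `O=C(Nc1ccc(NCc2cc(Cl)cc(C(F)(F)F)c2)cc1Cl)c1cc(Cl)ccc1O`: 30900 nM

Compound 1 and compound 2 share a core and differ in one place, (fluoro in place of chloro on an aromatic carbon). That change gave a 1.1-fold lower number from compound 2 to compound 1 (0.04 log units; within the scatter). Compound 3 carries a different core; how it differs from compound 2 is not broken down here, and its value stands within the scatter of both compound 1 and compound 2.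

Compound 4, `O=C(Nc1ccc(NCc2cc(F)cc(C(F)(F)F)c2)cc1Cl)c1cc(Cl)ccc1O`, is not yet measured. It differs from compound 3 by fluoro in place of chloro on an aromatic carbon. Among the compounds with values here, this is the same kind of change as the one from compound 2 to compound 1, but not the same: in compound 1 the fluoro sits "para to a large group", whereas in compound 4 it sits "meta to a large group; meta to a trifluoromethyl group". Within the data shown here, since the one measured instance of this change, a 1.1-fold lower number from compound 2 to compound 1 (0.04 log units; within the scatter), was within the scatter, compound 4 is expected to show a step of a 1.1-fold lower number from compound 3 to compound 4 (0.03 log units; within the scatter) from compound 3 in this assay, within the scatter. Compound 4 is therefore estimated at 29000 nM, with a range from 14000 nM to 60000 nM.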

Compound 4, half-maximal cytotoxic concentration: 30900 nM
The estimate for compound 4 lay 1.1-fold (0.03 log units) below the measured number; low and high end bracket the measured number.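

In this assay, putting fluoro in place of chloro on the aromatic carbon gave no change at the digits printed from compound 3 to compound 4 (within the scatter). Set beside the earlier instance of this change, the new step agrees with it: the same change on two cores in this assay, a 1.1-fold lower number (0.04 log units; within the scatter) from compound 2 to compound 1 and no change at the digits printed (within the scatter) from compound 3 to compound 4, 1.1-fold (0.04 log units) apart, within the scatter of two such steps

So on these two cores the exchange of chloro for fluoro left the number within the scatter, whether the fluoro stood para to a large group or meta to a large group and meta to a trifluoromethyl group; this shows only that the two steps agree on these two cores in this one read-out, and it neither establishes a rule for other cores nor reveals why the steps are so small.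

The compounds shown leave open whether a different group at these places, such as an amine, a methoxy group or a carboxylic acid, would move the number beyond the scatter. They also leave open what the trifluoromethyl group contributes on its own, since no pair shown differs by that group alone.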